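Removing the group from the amine nitrogen of compound 3

A few compounds are considered here, and "the series" means these few. Any claim that something is new, unique, unknown or untested is made for them only; others in the source may bear on it.

Measured in a functional assay on HepG2 cells (Homo sapiens) for inhibition, read by MTT assay, with a stated time of 48 h (on this read-out lower numbers stand for stronger inhibition and higher numbers for weaker inhibition), so far:
Compound 1 `CCOC(=O)C1=C(NN=C(C(C)=O)C(C)=O)Nc2[nH]nc(C)c2C1c1ccc(N(C)C)cc1` gives 8480 nM
Compound 2 `CCOC(=O)C1=C(N/C=N/c2nnc(S(N)(=O)=O)s2)Nc2[nH]nc(C)c2C1c1ccc(N(C)C)cc1` gives 38100 nM
Compound 3 `CCOC(=O)C1=C(N/C=N/c2ccc(C)cc2)Nc2[nH]nc(C)c2C1c1ccc(N(C)C)cc1` gives 44400 nM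

Compound 3 stands at the high end of these numbers. It lies level with compound 2, as a 1.2-fold higher number from compound 2 to compound 3 (0.07 log units; within the scatter) shows, and both lie above compound 1. Compound 4 `CCOC(=O)C1=C(N)Nc2[nH]nc(C)c2C1c1ccc(N(C)C)cc1` is reached from compound 3 by one change: a hydrogen atom in place of a group of 9 heavy atoms (8 carbon, 1 nitrogen; one six-membered aromatic ring of carbon only), on an amine nitrogen on the shared core. For the measured compounds named here, no measured step takes a group off this nitrogen altogether, so the evidence is only indirect. Exchanging groups on it gave a 5.2-fold higher number from compound 1 to compound 3 (0.72 log units; beyond the scatter) and a 4.5-fold higher number from compound 1 to compound 2 (0.65 log units; beyond the scatter) as the two modest steps seen so far. Both steps start from compound 1, and neither shows what a bare hydrogen would do. A modest move in this assay towards a lower number is therefore expected, with real doubt about its direction. The expected step is a 1.8-fold lower number from compound 3 to compound 4 (0.25 log units; within the scatter) as an estimate. The estimated value for compound 4 is 25000 nM (expected range 8000 nM to 70000 nM).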

Compound 4, half-maximal inhibitory concentration: 4240 nM
Compound 4: the middle estimate sits 5.9-fold (0.77 log units) above what was measured, and the stated range ends above it.
By their numbers in this assay, from the lowest: compounds 4 and 1 (each within the scatter of the next); then compounds 2 and 3 (each within the scatter of the next).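

In this assay a bare hydrogen atom on this amine nitrogen costs nothing: a 10-fold lower number from compound 3 to compound 4 (1.02 log units; beyond the scatter) comes with the loss of the group of 9 heavy atoms, and a 9.0-fold lower number from compound 2 to compound 4 (0.95 log units; beyond the scatter) with the loss of the group of 11 heavy atoms, so neither ring-bearing group is needed for inhibition here. The group of 8 heavy atoms in compound 1 stands apart, since a 2.0-fold lower number from compound 1 to compound 4 (0.30 log units; within the scatter) leaves that compound level with the free amine, and the groups on this nitrogen are therefore not alike in what they give up. Nothing at hand says why these groups part ways.

The compounds shown leave open whether a small group on this nitrogen, such as methyl or acetyl, would hold the number of compound 4 or shift it. They also leave open whether the free amine keeps its standing when the ethyl ester on the shared core gives way to a carboxylic acid or an amide.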